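Aryl group variation toward the dimethylphenyl analogue, compound 4

The compounds below may be only part of what the source reports. "The series", "measured", "known", "first", "only" and "open" are said of these compounds alone.

The series varies the aryl group on the shared core, assessed in an assay on microsomes from liver for inhibition of 3-hydroxy-3-methylglutaryl-coenzyme A reductase (Rattus norvegicus); on this read-out lower numbers stand for stronger inhibition and higher numbers for weaker inhibition. Compound 1 `O=C(O)C[C@H](O)C[C@H](O)CCn1c(C(F)(F)F)nc(-c2ccc(F)cc2)c1-c1ccccc1` gives 201 nM in this assay. Compound 2 `Cc1cccc(-c2c(-c3ccc(F)cc3)nc(C(F)(F)F)n2CC[C@@H](O)C[C@@H](O)CC(=O)O)c1` gives 74 nM. Compound 3 `O=C(O)C[C@H](O)C[C@H](O)CCn1c(C(F)(F)F)nc(-c2ccc(F)cc2)c1-c1ccc(C(F)(F)F)cc1` is reported only as a limit, > 1000 nM, which is the assay limit of > 1000 nM in this assay, at which 1 of the 3 values shown sits, and not a number; compound 3 thus stands at the weak end of the three values, with no measured figure of its own.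

The measured steps: a 2.7-fold lower number from compound 1 to compound 2 (0.43 log units; beyond the scatter); an at least 4.9-fold higher number from compound 1 to compound 3 (0.69 log units; beyond the scatter); an at least 13-fold higher number from compound 2 to compound 3 (1.13 log units; beyond the scatter). Among the measured compounds shown here, the one step that adds a methyl to the aryl group is a modest gain, and both steps that bring in trifluoromethyl on that ring lose, to the limit.

Compound 4 `Cc1cc(C)cc(-c2c(-c3ccc(F)cc3)nc(C(F)(F)F)n2CC[C@@H](O)C[C@@H](O)CC(=O)O)c1` differs from compound 3 by 3,5-dimethylphenyl in place of 4-(trifluoromethyl)phenyl on an aromatic carbon. This reverses the large losing step and goes one methyl beyond compound 2, so a large drop in number is expected, in the direction of compound 2 and possibly somewhat further, given a 2.7-fold lower number from compound 1 to compound 2 (0.43 log units; beyond the scatter). For compound 4 the estimate in this assay is 55 nM, with a range of 20 nM to 150 nM. This estimate corresponds to an expected step of an at least 18-fold lower number from compound 3 to compound 4 (1.25 log units; beyond the scatter).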

Compound 4, half-maximal inhibitory concentration: 38 nM
Compound 4: the middle estimate sits 1.4-fold (0.16 log units) above what was measured, within the range that was stated.
By their numbers in this assay, from the lowest: compounds 4 and 2 (each within the scatter of the next); then compound 1. At a limit, above all of these: compound 3.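

In this assay, adding a further methyl to the aryl group gives a 1.9-fold lower number from compound 2 to compound 4 (0.29 log units; within the scatter), so the second methyl cannot be told apart from the single methyl already present. Replacing phenyl with 3,5-dimethylphenyl gives a 5.3-fold lower number from compound 1 to compound 4 (0.72 log units; beyond the scatter), which shows that this position accepts two methyl groups on the aryl ring with no loss and that the gain over the unsubstituted phenyl stays beyond the scatter. Replacing 4-(trifluoromethyl)phenyl with 3,5-dimethylphenyl gives an at least 26-fold lower number from compound 3 to compound 4 (1.42 log units; beyond the scatter), a step that is only a bound, as compound 3 is held as a limit of the assay and not as a number: the limit of > 1000 nM in this assay, at which 1 of the 4 values shown sits.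

The compounds shown leave open whether the loss in compound 3 goes with the trifluoromethyl group itself or with where it sits on the ring, a question that a 3-(trifluoromethyl)phenyl or a 4-methylphenyl group at the same place would address. Also open, on these data alone, is how far the tolerance at this position extends beyond methyl, for example to a 3,5-dichlorophenyl or a 3,5-dimethoxyphenyl group.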